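Thiourea aryl halide exchange: chloro to bromo

The source may report more compounds than this note shows. Statements on the series, on what has been measured and on what is new or still open speak of the compounds shown alone.

Measured so far:
compound 1 `NC(=O)c1c(NC(=O)c2ccccc2)sc2c1CCN(C(=S)Nc1ccccc1Cl)C2`: 11800 nM
compound 2 `NC(=O)c1c(NC(=O)c2ccccc2I)sc2c1CCN(C(=S)Nc1ccccc1Cl)C2`: 17500 nM
compound 3 `COc1ccccc1C(=O)Nc1sc2c(c1C(N)=O)CCN(C(=S)Nc1ccccc1Cl)C2`: 20500 nM

In a functional assay on MKN-74 cells (Homo sapiens) for antiproliferative activity, with a stated time of 24 h (a lower number here means a stronger inhibitor, a higher number a weaker inhibitor), compound 2 stands second highest of the three numbers. Its nearest neighbour is compound 3, separated by a 1.2-fold higher number from compound 2 to compound 3 (0.07 log units; within the scatter), and its furthest is compound 1, separated by a 1.5-fold higher number from compound 1 to compound 2 (0.17 log units; within the scatter); both gaps lie within the scatter, so the three compounds cannot be ranked against each other.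

Compound 4 `NC(=O)c1c(NC(=O)c2ccccc2I)sc2c1CCN(C(=S)Nc1ccccc1Br)C2` differs from compound 2 by bromo in place of chloro on an aromatic carbon. For the measured compounds named here, no measured step touches the thiourea-side aryl ring: the three known steps, a 1.5-fold higher number from compound 1 to compound 2 (0.17 log units; within the scatter), a 1.7-fold higher number from compound 1 to compound 3 (0.24 log units; within the scatter) and a 1.2-fold higher number from compound 2 to compound 3 (0.07 log units; within the scatter), all change the benzamide ring, and each stayed within the scatter. Going by the values given here, they show only that small substituent changes on an aryl ring of this core have so far left this assay unmoved. A halogen-for-halogen exchange on the other ring is therefore expected to give no step beyond the scatter, in either direction, as a 1.0-fold lower number from compound 2 to compound 4 (0.01 log units; within the scatter).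

Compound 4 is accordingly estimated at 17000 nM, with a range from 8000 nM to 36000 nM.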

Compound 4, half-maximal inhibitory concentration: 22400 nM
The estimate for compound 4 lay 1.3-fold (0.12 log units) below the measured number; the range from low to high includes it.
By their numbers in this assay, from the lowest: compounds 1, 2, 3 and 4 (each within the scatter of the next).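

The 2-chlorophenyl to 2-bromophenyl exchange is the first step shown on the thiourea-side aryl ring, and in this assay it reads as (a 1.3-fold higher number from compound 2 to compound 4 (0.11 log units; within the scatter)). For the compounds shown here, the earlier steps all lay on the benzamide ring, so this is the first sign that a substituent ortho to a large group on the other ring can also be exchanged without a step beyond the scatter, though this rests on a single halogen pair on one background. No measured evidence here bears on the reason for this result.

Open, from the compounds shown here alone, is whether this place responds to a group other than a halogen, such as an amine or a carboxylic acid, or to hydrogen in place of the halogen. Also open, going by these compounds, is whether the same exchange reads alike with the unsubstituted benzamide of compound 1.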